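Swapping the naphthalene amide of compound 1 for a bromophenyl amide

The source may report more compounds than this note shows. Statements on the series, on what has been measured and on what is new or still open speak of the compounds shown alone.

Compound 1 `O=C(NO)c1ccc(NC(=O)[C@@H](NC(=O)c2ccc3ccccc3c2)c2ccccc2)cc1` is the starting point. In an assay on isolated protein for inhibition of protein deacetylase HDAC6 (Homo sapiens), read by fluorescence, with a stated time of 30 min (a higher number here means a weaker inhibitor, a lower number a stronger inhibitor), compound 1 gives 376 nM. Two related compounds have also been measured: compound 2 `O=C(NO)c1ccc(NC(=O)[C@@H](NS(=O)(=O)c2cccc3ccccc23)c2ccccc2)cc1` gives 295 nM in this assay, and compound 3 `CN(C)c1cccc2c(S(=O)(=O)N[C@H](C(=O)Nc3ccc(C(=O)NO)cc3)c3ccccc3)cccc12` gives 366 nM. The three numbers sit close together, and none of the gaps between them reaches beyond the usual scatter of repeated measurements, so compound 1 cannot be set apart from either of the other two on these data. For the measured compounds named here, the only step measured between two of them, a 1.2-fold higher number from compound 2 to compound 3 (0.09 log units; within the scatter), shows that putting a dimethylamino group on an aromatic carbon left the number essentially where it was.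

Compound 4 `O=C(NO)c1ccc(NC(=O)[C@@H](NC(=O)c2cccc(Br)c2)c2ccccc2)cc1` differs from compound 1 in one place: 3-bromophenyl in place of naphthalen-2-yl on a carbonyl carbon. Going by the values given here, no measured step touches this kind of exchange; the single step on record concerns a different substituent on a different compound, and it was flat. With nothing pointing firmly in either direction, the step of a 1.2-fold higher number from compound 1 to compound 4 (0.08 log units; within the scatter) is expected to be modest and may well stay within the scatter. Compound 4 is therefore estimated at 450 nM, with a plausible range from 150 nM to 1400 nM.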

Compound 4, half-maximal inhibitory concentration: 196 nM
Beside the measured number, compound 4's estimate is 2.3-fold (0.36 log units) above it, and the stated range covers the measured number.
By their numbers in this assay, from the lowest: compounds 4, 2, 3 and 1 (each within the scatter of the next).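

In this assay, putting 3-bromophenyl in place of naphthalen-2-yl on a carbonyl carbon gives a 1.9-fold lower number from compound 1 to compound 4 (0.28 log units; within the scatter), so this exchange cannot be told apart from the ordinary spread of repeated measurements. Among the compounds shown, only this pair differs in the group on this carbonyl carbon, and it shows that a group with one six-membered aromatic ring and 7 heavy atoms can stand here, in place of one with 2 such rings and 10 heavy atoms, without a measurable change in the number. No supporting measurement bears on this result, so it stands as an observation without an explanation.

The bromine and the ring that carries it remain unseparated, since a plain phenyl group, or a phenyl group with chlorine or methoxy in place of the bromine, would be needed to show what the bromine itself contributes. Going by these compounds, whether this position needs an aromatic ring at all also remains open, and a cyclohexyl group or a short alkyl chain on the same carbonyl carbon would test that.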